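A few compounds are considered here, and "the series" means these few. Any claim that something is new, unique, unknown or untested is made for them only; others in the source may bear on it.

Going by the values given here, in a functional assay on NCI-H1975 cells (Homo sapiens) for antiproliferative activity, with a stated time of 72 h (a higher number here means a weaker inhibitor of growth, a lower number a stronger inhibitor of growth), compound 2 `O=C(NCc1ccccc1)c1cc(Cl)c(O)cc1O` gives 86200 nM, the highest of the three numbers so far, so it is the weakest inhibitor of growth measured. Compound 3 `CCNC(=O)c1ccc(CN(C)C(=O)c2cc(C(C)C)c(O)cc2O)cc1` gives 460 nM. Compound 4 `CN(Cc1ccccc1)C(=O)c1cc(Cl)c(O)cc1O` is compound 2 with methyl in place of hydrogen on an amide-type nitrogen. Among the compounds with values here, no measured pair shows this change alone. Compound 1 `COc1ccc(CN(C)C(=O)c2cc(Cl)c(O)cc2O)cc1OC` also carries that methyl but differs elsewhere too, and it gives 33400 nM. A small expected move toward a lower number, a 1.7-fold lower number from compound 2 to compound 4 (0.24 log units; within the scatter), may well stay within the usual scatter. For compound 4 the estimated value is 50000 nM, with an expected range of 20000 nM to 120000 nM.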

Compound 4, concentration for 50% growth inhibition: 35500 nM
Beside the measured number, compound 4's estimate is 1.4-fold (0.15 log units) above it, within the range that was stated.
By their numbers in this assay, from the lowest: compound 3; then compounds 1 and 4 (each within the scatter of the next); then compound 2.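

Putting methyl in place of hydrogen on the amide-type nitrogen gives a 2.4-fold lower number from compound 2 to compound 4 (0.39 log units; beyond the scatter) in this assay and shows this change on its own, whereas compound 1 carried it along with other differences. The step is modest but lies beyond the usual scatter, so in this pair the amide hydrogen can be given up without loss of growth inhibition. Nothing measured here explains the shift. Going by these compounds, whether ethyl or a longer chain on that nitrogen would move the number further remains open. So does whether methyl would give a step of similar size on the core of compound 3.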